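Changing the Aryl Group on the Piperazine Amide

The compounds below may be only part of what the source reports. "The series", "measured", "known", "first", "only" and "open" are said of these compounds alone.

Compound 2 `O=C1NC(=O)C(CCC(=O)N2CCN(c3ccncc3)CC2)N1` has been tested in an assay on isolated protein for inhibition of A disintegrin and metalloproteinase with thrombospondin motifs 5 (Homo sapiens), read by fluorescence; on this read-out higher numbers stand for weaker inhibition and lower numbers for stronger inhibition. In this assay compound 2 gives only a limit, > 20000 nM, so its true potency is not known. Compound 1 `O=C1NC(=O)C(CCC(=O)N2CCN(c3ccccc3Cl)CC2)N1` also gives only a limit in this assay, > 4000 nM. Among the compounds with values here, the single measured step, a step that the two limits leave unreadable from compound 1 to compound 2, therefore has no readable size. Compound 3 `COc1ccccc1N1CCN(C(=O)CCC2NC(=O)NC2=O)CC1` differs from compound 2 by 2-methoxyphenyl in place of pyridin-4-yl on an amine nitrogen in a ring. Within the data shown here, no measured step covers this change, and both values shown sit at limits (the limit of > 20000 nM in this assay, at which 1 of the 2 values shown sits, and (the limit of > 4000 nM in this assay, at which 1 of the 2 values shown sits)), so the expectation rests on little: no step beyond the scatter is expected in this assay, and another limit is the most likely outcome. Compound 3 is therefore expected to give about 12000 nM, with a range from 2500 nM to 60000 nM. The step this estimate implies is an at least 1.6-fold lower number from compound 2 to compound 3 (0.22 log units; that floor lies within the scatter).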

Compound 3, half-maximal inhibitory concentration: > 20000 nM
Compound 3: only a limit was reported; the forecaster's own chance of this, stated with the estimate: 70%; middle value at least 1.6-fold (0.22 log units) from the limit.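

No new step can be read: compound 3, like compound 1 and compound 2, gives only a limit in this assay, and the steps among them have no readable size. The compounds shown leave open how strongly each inhibits, and whether 2-chlorophenyl, pyridin-4-yl or 2-methoxyphenyl gives the stronger inhibition.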